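Swapping an aryl group on a piperazine in a triazine series

This account rests on a few compounds, and the source may have more. Where it says the series, first, only, none or still open, it means among the compounds named here.

Measured so far:
- compound 1 `N#Cc1ccc(Nc2nc(Oc3ccnc4ccccc34)nc(N3CCN(c4cccc(C(F)(F)F)c4)CC3)n2)cc1C(F)(F)F`: > 100000 nM
- compound 2 `N#Cc1ccc(Nc2nc(Oc3ccnc4ccccc34)nc(N3CCC(Cc4ccccc4)CC3)n2)cc1C(F)(F)F`: > 100000 nM
- compound 3 `N#Cc1ccc(Nc2nc(Oc3ccnc4ccccc34)nc(N3CCN(C(c4ccccc4)c4ccccc4)CC3)n2)cc1C(F)(F)F`: > 100000 nM

In a functional assay on DU-145 cells (Homo sapiens) for cytotoxicity, read by sulforhodamine B assay, with a stated time of 48 h (a lower number here means that less compound is tolerated, a higher number that more compound is tolerated), compound 1 reaches only a limit of the assay, > 100000 nM; that is not a number. The same holds for the other two compounds, which is all the evidence here: the limit of > 100000 nM in this assay, at which 3 of the 3 values shown sit. Compound 4 `N#Cc1ccc(Nc2nc(Oc3ccnc4ccccc34)nc(N3CCN(c4cccc(Cl)c4Cl)CC3)n2)cc1C(F)(F)F` differs from compound 1 in one place: 2,3-dichlorophenyl in place of 3-(trifluoromethyl)phenyl on an amine nitrogen in a ring. For the measured compounds named here, no step between measured compounds is known, so the step from compound 1 to compound 4 can only be guessed. Compound 4 is expected to sit at the same limit, a change of a number no higher from compound 1 to compound 4 (the limit leaves the size open), none beyond the scatter. The estimate for compound 4 is 100000 nM, within 40000 nM to 300000 nM.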

Compound 4, concentration lethal to 50% of the cells: > 100000 nM
Compound 4 ended at the assay's limit (the forecaster's own chance of this, stated with the estimate: 85%); the middle value lies on the limit itself.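

For the compounds shown here, compound 1 and compound 4 both stand at a limit rather than a number, and no step between them can be read. The compounds shown leave open where their true lethal concentrations lie, and whether 2,3-dichlorophenyl and 3-(trifluoromethyl)phenyl differ at all.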